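Compound 3: Diethylamino Replaces Amino at the Carbonyl

The compounds below may be only part of what the source reports. "The series", "measured", "known", "first", "only" and "open" are said of these compounds alone.

Compound 1 `CCCC(=O)C1=C(C)NC(=O)NC1c1ccsc1`: 1% in an assay on membranes from HeLa cells for displacement of a labelled ligand from adenosine receptor A3 (Homo sapiens), read by scintillation counting, with a stated time of 180 min, tested at 1 uM; a higher number here means more inhibition at the concentration tested (going by the name of the read-out), a lower number less inhibition
Compound 2 `CC1=C(C(N)=O)C(c2ccsc2)NC(=O)N1`: 1%

Compound 2 stands level with compound 1: no change at the digits printed from compound 1 to compound 2 (within the scatter), a step that swapped one group on the carbonyl carbon and moved nothing. Compound 3 `CCN(CC)C(=O)C1=C(C)NC(=O)NC1c1ccsc1` differs from compound 2 by diethylamino in place of amino on a carbonyl carbon. Among the compounds with values here, the only measured step touches the same carbonyl carbon, and it stayed flat, so a flat result is expected again, with a number 1 percentage points higher from compound 2 to compound 3 (within the scatter) reflecting no change beyond the scatter. Compound 3 is therefore estimated at 2%, in a range from 0% to 12%.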

Compound 3, a percentage reported as inhibition, at one concentration (the size of the read-out at that concentration, not a potency): 35%
Compound 3: the middle estimate sits 33 percentage points below what was measured, and the stated range ends below it.
By their numbers in this assay, from the lowest: compounds 1 and 2 (each within the scatter of the next); then compound 3.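

In this assay the group on this carbonyl carbon does change the result: diethylamino in place of amino gives a number 34 percentage points higher from compound 2 to compound 3 (beyond the scatter). Diethylamino in place of propyl gives a number 34 percentage points higher from compound 1 to compound 3 (beyond the scatter), so the flat step between amino and propyl did not mean that this position makes no difference. Nothing available here explains the rise. The compounds shown leave open how a dimethylamino, an ethylamino or a piperidine group on this carbonyl carbon would compare with diethylamino.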